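Compound 3 and the step to a propyl group

A few compounds are considered here, and "the series" means these few. Any claim that something is new, unique, unknown or untested is made for them only; others in the source may bear on it.

Values in a functional assay on HepG2 cells (Homo sapiens) for antiproliferative activity, read by MTT assay, with a stated time of 48 h (a higher number here means a weaker inhibitor, a lower number a stronger inhibitor), are as follows.
Compound 1 `Clc1cccc(Nc2ncnc3ccc(NCc4cccnc4)cc23)c1` gives 4140 nM in this series.
Compound 2 `Clc1cccc(Nc2ncnc3ccc(NCc4cccs4)cc23)c1` gives 3580 nM in this series.
Compound 3 `Clc1cccc(Nc2ncnc3ccc(NCc4c[nH]c5ccccc45)cc23)c1` gives 5260 nM in this series.

Compound 3 cannot be separated from the other two measured compounds, with a 1.3-fold higher number from compound 1 to compound 3 (0.10 log units; within the scatter) and a 1.5-fold higher number from compound 2 to compound 3 (0.17 log units; within the scatter) as its two steps. The remaining pair shows a 1.2-fold lower number from compound 1 to compound 2 (0.06 log units; within the scatter) as well.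

The next structure is compound 4 `CCCCNc1ccc2ncnc(Nc3cccc(Cl)c3)c2c1` and the change is propyl in place of 1H-indol-3-yl on a saturated chain carbon bound to a nitrogen on an aromatic ring in the form of propyl in place of 1H-indol-3-yl on a saturated chain carbon bound to a nitrogen on an aromatic ring.

All three measured steps exchange one aromatic group for another at this place, and all stay within the scatter. None tests a group without a ring, so they bear on this change only loosely. The estimate means a 1.0-fold higher number from compound 3 to compound 4 (0.02 log units; within the scatter) as the expected step, so no shift beyond the scatter is expected, in either direction. The expected value for compound 4 is 5500 nM with an estimated range from 2500 nM to 13000 nM in this assay once it is measured.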

Compound 4, half-maximal inhibitory concentration: 7850 nM
The estimate for compound 4 lay 1.4-fold (0.15 log units) below the measured number, and the stated range covers the measured number.
By their numbers in this assay, from the lowest: compounds 2, 1, 3 and 4 (each within the scatter of the next, the first and the last beyond it).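

For the compounds shown here, compound 4 is the only compound here with a group without a ring at this place, on a saturated chain carbon bound to a nitrogen on an aromatic ring, and in this assay it gives the only step beyond the scatter, a modest one against the thiophen-2-yl group (a 2.2-fold higher number from compound 2 to compound 4 (0.34 log units; beyond the scatter)). The same change stays within the scatter against the 1H-indol-3-yl group (a 1.5-fold higher number from compound 3 to compound 4 (0.17 log units; within the scatter)) and the pyridin-3-yl group (a 1.9-fold higher number from compound 1 to compound 4 (0.28 log units; within the scatter)), so compound 3 and compound 1 go against any general loss on leaving out the ring. No measured finding accounts for this step.

Going by these compounds, whether a longer chain would follow propyl remains open. So does the outcome of an amine or a carboxylic acid at the end of the propyl chain.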